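This account rests on a few compounds, and the source may have more. Where it says the series, first, only, none or still open, it means among the compounds named here.

Compound 2 `O=C(CSc1nnc(-c2ccncc2)o1)N/N=C/c1ccccc1F` gives 21500 nM in a functional assay on SW 1116 cells (Homo sapiens) for cytotoxicity, read by MTT assay, with a stated time of 48 h; a higher number here means a weaker inhibitor, a lower number a stronger inhibitor. Among the measured compounds shown here, the only other number comes from compound 1 `O=C(CSc1nnc(-c2ccncc2)o1)N/N=C/c1ccc(Cl)cc1`, which gives 17000 nM, and the step of a 1.3-fold higher number from compound 1 to compound 2 (0.10 log units; within the scatter) leaves the two within the scatter of each other. Compound 3 `O=C(CSc1nnc(-c2ccncc2)o1)N/N=C/c1cc(Br)ccc1O` differs from compound 2 by 5-bromo-2-hydroxyphenyl in place of 2-fluorophenyl on a carbon with a double bond to nitrogen. For the measured compounds named here, the single measured step also swapped the ring at this same place and stayed within the scatter, so no step beyond the scatter is expected here, though the new ring carries a hydroxyl that neither earlier ring had. Compound 3 is therefore estimated at 15000 nM, within a range from 6000 nM to 40000 nM. This estimate means a 1.4-fold lower number from compound 2 to compound 3 (0.16 log units; within the scatter).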

Compound 3, half-maximal inhibitory concentration: 8150 nM
Compound 3: middle estimate off by 1.8-fold (0.26 log units), on the high side; measured number inside the range.
By their numbers in this assay, from the lowest: compound 3; then compounds 1 and 2 (each within the scatter of the next).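

This position can shift the number beyond the scatter: 5-bromo-2-hydroxyphenyl gives a 2.6-fold lower number from compound 2 to compound 3 (0.42 log units; beyond the scatter) and a 2.1-fold lower number from compound 1 to compound 3 (0.32 log units; beyond the scatter) at the same place, where the earlier ring swap did not. Both steps are modest, so compound 3 is a stronger inhibitor than either earlier compound, but only moderately so. Nothing measured here explains this gain. As far as these compounds go, the hydroxyl and the bromine enter together, so it remains open which of them carries the step. Also open, from the compounds shown here alone, is how an amine or a carboxylic acid on this ring would fare.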